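This account rests on a few compounds, and the source may have more. Where it says the series, first, only, none or still open, it means among the compounds named here.

Compound 1 `O=C1c2ccccc2S(=O)(=O)N1CCCCCN1CCN(c2ccc(Cl)cc2)CC1` gives 703 nM in an assay on HEK293 cells for displacement of a labelled ligand from 5-hydroxytryptamine receptor 6 (Homo sapiens); on this read-out lower numbers stand for stronger inhibition and higher numbers for weaker inhibition. Compound 2 `COc1ccccc1N1CCN(CCCCCCN2C(=O)c3ccccc3S2(=O)=O)CC1` gives 779 nM in this assay, a number within the scatter of compound 1, while compound 3 `O=C1c2ccccc2S(=O)(=O)N1CCCCCCN1CCN(c2ccc(Cl)cc2)CC1` gives 72 nM in this assay, a markedly lower number. The only single-point step among these three, an 11-fold lower number from compound 2 to compound 3 (1.03 log units; beyond the scatter), shows that the aryl group on the ring nitrogen can shift the read-out strongly. Compound 4 `O=C1c2ccccc2S(=O)(=O)N1CCCCCN1CCN(c2cccc(C(F)(F)F)c2)CC1` differs from compound 1 by 3-(trifluoromethyl)phenyl in place of 4-chlorophenyl on an amine nitrogen in a ring. For the measured compounds named here, no measured step covers this particular exchange; the one aryl step measured concerns a different pair of groups on a longer chain, so the direction is open. Compound 4 is therefore expected to give about 500 nM, between 150 nM and 2000 nM. The expected step is a 1.4-fold lower number from compound 1 to compound 4 (0.15 log units; within the scatter), not beyond the scatter.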

Compound 4, inhibition constant: 1350 nM
Compound 4: the middle estimate sits 2.7-fold (0.43 log units) below what was measured; measured number inside the range.
By their numbers in this assay, from the lowest: compound 3; then compounds 1, 2 and 4 (each within the scatter of the next).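

In this assay the exchange gives a 1.9-fold higher number from compound 1 to compound 4 (0.28 log units; within the scatter) on the chain of compound 1, so 3-(trifluoromethyl)phenyl and 4-chlorophenyl cannot be told apart on an amine nitrogen in a ring. This position therefore does not shift strongly with every aryl exchange, although the earlier step shows an 11-fold lower number from compound 2 to compound 3 (1.03 log units; beyond the scatter) on the longer chain. Nothing available explains this result. Still open, as far as these compounds go, is how 3-(trifluoromethyl)phenyl reads on that longer chain, and how an unsubstituted phenyl or a pyridine ring would read at this position.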